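A Longer Chain on Compound 2: What to Expect

The compounds below may be only part of what the source reports. "The series", "measured", "known", "first", "only" and "open" are said of these compounds alone.

Measured compounds:
compound 1, `CCCCOP(=O)(O)OC[C@H]1O[C@@H](n2ccc(N)nc2=O)[C@@H](O)[C@@H]1O`, 7.5 uM
compound 2, `CCCCCCCCOP(=O)(O)OC[C@H]1O[C@@H](n2ccc(N)nc2=O)[C@@H](O)[C@@H]1O`, 11 uM

Both were tested in a functional assay on L1210 cells (Mus musculus) for inhibition; a higher number here means a weaker inhibitor, a lower number a stronger inhibitor. Compound 1 gives 7.5 uM, and compound 2 gives 11 uM. The step of a 1.5-fold higher number from compound 1 to compound 2 (0.17 log units; within the scatter) is too small to count as a real difference. Compound 2 holds the higher of the two numbers, with compound 1 nearest to it, but that gap falls within the scatter, so the two compounds cannot be told apart on these data.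

Compound 3, `CCCCCCCCCCCCCCCCOP(=O)(O)OC[C@H]1O[C@@H](n2ccc(N)nc2=O)[C@@H](O)[C@@H]1O`, is the next member of the series. The change from compound 2 is octyl in place of hydrogen on a saturated chain carbon, eight bonds along the chain from an oxygen on an unsaturated carbon. Within the data shown here, the one measured step that bears on it is the same kind of change made earlier, a chain extended further from the same oxygen: a 1.5-fold higher number from compound 1 to compound 2 (0.17 log units; within the scatter). On that basis the step of a 1.1-fold higher number from compound 2 to compound 3 (0.04 log units; within the scatter) is expected to stay within the scatter as well, with no clear direction. Among the measured compounds shown here, the single prior step gives no sign that a longer chain strengthens or weakens inhibition. Compound 3 is therefore estimated at 12 uM, with a range from 4 uM to 40 uM.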

Compound 3, concentration for 50% inhibition: 11 uM
Beside the measured number, compound 3's estimate is 1.1-fold (0.04 log units) above it; the measured number falls inside the stated range.
By their numbers in this assay, from the lowest: compounds 1, 2 and 3 (each within the scatter of the next).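

The second lengthening adds what the first step could not show on its own: in this assay, octyl in place of hydrogen, eight bonds along the chain from an oxygen on an unsaturated carbon, gives no change at the digits printed from compound 2 to compound 3 (within the scatter). Even the larger change, dodecyl in place of hydrogen four bonds along the chain from that oxygen, gives only a 1.5-fold higher number from compound 1 to compound 3 (0.17 log units; within the scatter), so all three compounds stay within the scatter of one another, and this much added chain leaves no readable mark on the number in this cell assay. Nothing among the data given explains why the number holds steady across these chains.

The compounds shown leave open whether a different kind of chain end, such as an amine or a carboxylic acid, would move the number beyond the scatter. They also leave open how a chain shorter than butyl, such as methyl, or a plain hydrogen on that oxygen would compare with these three compounds.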